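Swapping a hydrazone for a pyridylmethyl imine on a coumarin-type core

This account rests on a few compounds, and the source may have more. Where it says the series, first, only, none or still open, it means among the compounds named here.

Compound 1, `C/C(=N\Cc1ccccc1)c1c(O)c2ccccc2[nH]c1=O`: >= 100000 nM
Compound 2, `C/C(=N\Nc1ccccc1)c1c(O)c2ccccc2oc1=O`: 27000 nM

Of the compounds shown here, two have been tested in an assay on isolated protein for inhibition of myosin-2 (Bos taurus), read by spectrophotometry, with a stated time of 24 min; a higher number here means a weaker inhibitor, a lower number a stronger inhibitor. Compound 1 gives only a limit of the assay, >= 100000 nM. Going by the values given here, compound 2 gives 27000 nM, the only actual number among the two, and so the only fixed point from which to reason. The result for compound 1 is a limit, as noted in the evidence (the limit of >= 100000 nM in this assay, at which 1 of the 2 values shown sits).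

Compound 3 is `C/C(=N\Cc1cccnc1)c1c(O)c2ccccc2oc1=O`. It keeps the core of compound 2 and changes one group: (pyridin-3-yl)methyl in place of anilino on a double-bonded nitrogen. Among the compounds with values here, no measured pair shows what such a change does here, so the size of the step is open. With compound 1, which also carries a methylene-linked aryl on that nitrogen, sitting at the limit, a move toward weaker inhibition seems more likely than stronger, though it could also stay within the scatter. Compound 3 is therefore estimated at 60000 nM, with a range from 20000 nM to 200000 nM, which means an expected step of a 2.2-fold higher number from compound 2 to compound 3 (0.35 log units; beyond the scatter).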

Compound 3, half-maximal inhibitory concentration: 17000 nM
Compound 3: middle estimate off by 3.5-fold (0.55 log units), on the high side; the measured number lies below the stated range.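

In this assay the exchange at this position gives a 1.6-fold lower number from compound 2 to compound 3 (0.20 log units; within the scatter). On the double-bonded nitrogen, then, (pyridin-3-yl)methyl and anilino cannot be told apart here, even though the hydrogen-bond donor of anilino is gone and the link to the ring is now a carbon. Compound 1 gives only a limit of the assay, not a number, and its structure differs from the others in more than one place, so no step to it can be read: the limit of >= 100000 nM in this assay, at which 1 of the 3 values shown sits.

Whether the ring nitrogen of the (pyridin-3-yl)methyl group matters stays open, as no compound shown pairs a methylene-linked ring of carbon only with this same core. As far as these compounds go, it is also open whether any group at this position can move the number beyond the scatter, for instance a longer chain or a carboxylic acid.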